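Swapping the 4-methylbenzyl group: compound 1 toward compound 4

A few compounds are considered here, and "the series" means these few. Any claim that something is new, unique, unknown or untested is made for them only; others in the source may bear on it.

Measured so far:
compound 1 `CNC(=O)c1cc(C(=O)NC2CC2)cn(Cc2ccc(C)cc2)c1=O`: 11 ug/mL
compound 2 `CNC(=O)c1cc(C(=O)NC2CC2)cn([C@H](C)c2ccccc2)c1=O`: 815 ug/mL
compound 3 `CNC(=O)c1cc(C(=O)NC2CC2)cn(Cc2cccc3cn[nH]c23)c1=O`: 131 ug/mL

Compound 1 `CNC(=O)c1cc(C(=O)NC2CC2)cn(Cc2ccc(C)cc2)c1=O` gives 11 ug/mL in a physicochemical assay for solubility, read by HPLC, in simulated intestinal fluid, with a stated time of 16 h, tested at 125 ug/mL (a higher number here means a more soluble compound, a lower number a less soluble compound), the lowest of the three numbers. Compound 3 `CNC(=O)c1cc(C(=O)NC2CC2)cn(Cc2cccc3cn[nH]c23)c1=O` sits nearest with 131 ug/mL, and compound 2 `CNC(=O)c1cc(C(=O)NC2CC2)cn([C@H](C)c2ccccc2)c1=O` furthest with 815 ug/mL. Both measured steps leave compound 1 and move upward: a 74-fold higher number from compound 1 to compound 2 (1.87 log units; beyond the scatter) and a 12-fold higher number from compound 1 to compound 3 (1.08 log units; beyond the scatter).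

Compound 4 `CNC(=O)c1cc(C(=O)NC2CC2)cn(Cc2ccccc2F)c1=O` is the next compound to be measured. It differs from compound 1 in one place: 2-fluorophenyl in place of 4-methylphenyl on a saturated chain carbon bound to an aromatic nitrogen.

Neither measured step changes exactly this part of the molecule, but both show that altering the group on the saturated chain carbon bound to the aromatic nitrogen of compound 1 has so far given large upward steps. The change to compound 4 keeps the same ring size and the same count of heavy atoms, so a smaller step is expected than either a 74-fold higher number from compound 1 to compound 2 (1.87 log units; beyond the scatter) or a 12-fold higher number from compound 1 to compound 3 (1.08 log units; beyond the scatter), most likely still upward. Compound 4 is therefore estimated at 50 ug/mL in this assay, with a range from 15 ug/mL to 200 ug/mL. The expected step from compound 1 is a 4.5-fold higher number from compound 1 to compound 4 (0.66 log units; beyond the scatter).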

Compound 4, solubility: 88 ug/mL
Estimate against measurement, compound 4: 1.8-fold (0.25 log units) below, within the range that was stated.
By their numbers in this assay, from the lowest: compound 1; then compounds 4 and 3 (each within the scatter of the next); then compound 2.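

Even with the same heavy-atom count and the same kind of aromatic ring, 2-fluorophenyl in place of 4-methylphenyl gives an 8.0-fold higher number from compound 1 to compound 4 (0.90 log units; beyond the scatter) in this assay, so this position responds to a change that keeps both. Set against the 1H-indazol-7-yl group, the result is a 1.5-fold lower number from compound 3 to compound 4 (0.17 log units; within the scatter), so these two groups cannot be told apart here. The 2-fluorobenzyl group still trails 1-phenylethyl on the aromatic nitrogen, with a 9.3-fold lower number from compound 2 to compound 4 (0.97 log units; beyond the scatter), so this swap does not close that gap.

The change removes a methyl and adds a fluorine at once, and the compounds shown leave open what each does alone. On these data alone, what a plain benzyl group would give also stays open, as does a benzyl ring carrying an amine or a carboxylic acid.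

Nothing measured here explains why any of these steps occurs.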